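The compounds below may be only part of what the source reports. "The series", "measured", "known", "first", "only" and "open" are said of these compounds alone.

In an ADME assay on microsomes from liver (Homo sapiens) for metabolic stability, read by LC-MS, using NADPH, with a stated time of 30 min, tested at 0.1 uM, in the presence of a further agent that is not named here (a lower number here means that less of the compound is left, a higher number that more of the compound is left), two compounds have been measured so far:

- compound 1 `Nc1ncc(-c2ccc(C(=O)N3CCC(O)C3)cc2)nc1-c1ccc(C(F)(F)F)cc1`: > 90%
- compound 2 `Nc1ncc(-c2ccc(C(=O)N3CC[C@@H](O)C3)cc2)nc1-c1ccc(C(F)(F)F)cc1`: > 90%

Each of these two readings is a limit and not a number. Compound 2 therefore has no exact position, and all that the pair shows is the limit of > 90% in this assay, at which 2 of the 2 values shown sit. For the measured compounds named here, the one measured step is a step that the two limits leave unreadable from compound 1 to compound 2. It concerns only (the fact that one of compounds 1 and 2 is drawn with a defined configuration and the other without, at the place where they differ), so it offers no size to carry forward.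

Compound 3 `Nc1ncc(-c2ccc(C(=O)N3CCC(O)CC3)cc2)nc1-c1ccc(C(F)(F)F)cc1` keeps the core of compound 2 and makes one change: 4-hydroxypiperidin-1-yl in place of 3-hydroxypyrrolidin-1-yl on a carbonyl carbon. The five-membered non-aromatic ring gives way to a six-membered one, and the defined stereocentre is lost. Going by the values given here, no measured step alters the ring in this way, which makes any forecast a cautious one.

The expectation rests on compound 2 with its limit of > 90%. The expected change is a number no higher from compound 2 to compound 3 (the limit leaves the size open), with no clear direction and no size beyond the usual scatter of this assay. For compound 3, the estimate is 90%, with an expected range from 75% to 100%.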

Compound 3, percent of the compound remaining: > 90%
Compound 3: only a limit was reported; the forecaster's own chance of this, stated with the estimate: 50%; the middle value lies on the limit itself.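

Compound 3 gives a limit and not a number in this assay, as do compound 1 and compound 2, so the steps from compound 1 and compound 2 to compound 3 cannot be read: the limit of > 90% in this assay, at which 3 of the 3 values shown sit.

The compounds shown leave open whether 4-hydroxypiperidin-1-yl in place of 3-hydroxypyrrolidin-1-yl changes the percent remaining in this assay, and by how much.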